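The source may hold more compounds than are shown below. What is called first, only, known or untested is meant among the compounds shown, and "the series" means these compounds.

Compound 1, `Cc1cc(Cl)nnc1N1CCN(c2ncccn2)CC1`: in a functional assay on BV-2 cells (Mus musculus) for inhibition, read by ELISA, with a stated time of 16 h (a higher number here means a weaker inhibitor, a lower number a stronger inhibitor), compound 1 gives only a limit, > 100000 nM.
Compound 2, `Cc1ccnnc1N1CCN(c2ncccn2)CC1`: in this assay compound 2 gives only a limit, > 100000 nM.
Compound 3, `Cc1cc(C(C)C)nnc1N1CCN(c2ncccn2)CC1`: in this assay compound 3 gives only a limit, > 100000 nM.

Compound 3 therefore stands where the whole set stands, at the limit of > 100000 nM in this assay, at which 3 of the 3 values shown sit. Every value is a limit. The three steps between the measured compounds, a step that the two limits leave unreadable from compound 1 to compound 2, a step that the two limits leave unreadable from compound 1 to compound 3 and a step that the two limits leave unreadable from compound 2 to compound 3, cannot be read in size or direction; they show only that none of the three compounds produced a measurable inhibition.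

Compound 4, `Cc1cc(-c2cccc(F)c2)nnc1N1CCN(c2ncccn2)CC1`, has not been measured. It differs from compound 3 by 3-fluorophenyl in place of isopropyl on an aromatic carbon. For the measured compounds named here, no measured step exchanges an isopropyl for an aromatic ring, and the steps that are known are all unreadable, so they offer no expected size and no expected direction for this change. As far as these compounds go, the most that can be said is that a larger group at this position is untested.

Compound 4 is estimated to give 50000 nM in this assay, expected between 5000 nM and 300000 nM, and the step of an at least 2.0-fold lower number from compound 3 to compound 4 (0.30 log units; that floor lies within the scatter) is likewise an expectation only, with a real chance that compound 4 again gives only a limit.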

Compound 4, half-maximal inhibitory concentration: 33500 nM
For compound 4 the middle estimate is 1.5-fold (0.17 log units) above the measured one; the range from low to high includes it.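

For the compounds shown here, the 3-fluorophenyl group is the first group at this position to give a real number rather than a limit in this assay. Measured against the three earlier compounds, it gives an at least 2.9-fold lower number from compound 3 to compound 4 (0.47 log units; beyond the scatter) and an at least 2.9-fold lower number from compound 2 to compound 4 (0.47 log units; beyond the scatter) and also an at least 2.9-fold lower number from compound 1 to compound 4 (0.47 log units; beyond the scatter) and each of these sizes is only a floor, so the true steps may be larger. Among these four compounds, only the one with an aromatic ring at this position leaves the limit, while the chloro, hydrogen and isopropyl compounds stay there: (the limit of > 100000 nM in this assay, at which 3 of the 4 values shown sit).

Still open, as far as these compounds go, is whether the ring alone accounts for this step or the fluorine also contributes, a question that a plain phenyl group would help to settle. Also open, from the compounds shown here alone, is how the number would respond to a pyridine ring, a methoxy group or an amine at this position.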